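The source may report more compounds than this note shows. Statements on the series, on what has been measured and on what is new or still open speak of the compounds shown alone.

In an ADME assay on HII4E cells (Mus musculus) for cytotoxicity, read by MTT assay, with a stated time of 48 h (on this read-out lower numbers stand for stronger inhibition and higher numbers for weaker inhibition), three compounds have been measured so far. Compound 1 (`CCCCCCCCCCCCNC(=O)CO[C@H]1O[C@H](COC(C)=O)C=C(OC(C)=O)C1=O`) gives 136 ug/mL, and compound 2 (`CCCCCCCCCCCCNC(=O)CO[C@@H]1O[C@H](COC(C)=O)C=C(OC(C)=O)C1=O`) gives 45 ug/mL. Compound 3 (`C=CCNC(=O)CO[C@H]1O[C@H](COC(C)=O)C=C(OC(C)=O)/C1=C\C(=O)OCC`) gives 352 ug/mL, the highest of the three numbers, which makes it the weakest inhibitor of the set on this read-out.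

Compound 4 (`C#CCNC(=O)CO[C@H]1O[C@H](COC(C)=O)C=C(OC(C)=O)/C1=C\C(=O)OCC`) has not been measured yet and differs from compound 3 in one place: ethynyl in place of vinyl on a saturated chain carbon bound to an amide-type nitrogen. In words, ethynyl stands in place of vinyl on a saturated chain carbon bound to an amide-type nitrogen, a difference that can also be read as allyl to propargyl.

Going by the values given here, the only measured step available is a 3.0-fold lower number from compound 1 to compound 2 (0.48 log units; beyond the scatter). Among the compounds with values here, it concerns (the fact that compounds 1 and 2 differ only in the configuration as drawn), so it offers no guide to the size of an allyl to propargyl change, and no measured pair shows that change directly. The best anchor is therefore compound 3 at 352 ug/mL, and no step beyond the scatter is expected in this assay.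

The estimate corresponds to an expected 1.1-fold lower number from compound 3 to compound 4 (0.04 log units; within the scatter).

Compound 4 is expected to give about 320 ug/mL, with an estimated range from 140 ug/mL to 700 ug/mL.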

Compound 4, half-maximal inhibitory concentration: 257 ug/mL
Beside the measured number, compound 4's estimate is 1.2-fold (0.10 log units) above it; the measured number falls inside the stated range.
By their numbers in this assay, from the lowest: compound 2; then compounds 1, 4 and 3 (each within the scatter of the next, the first and the last beyond it).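

In this assay, going by these compounds alone, the allyl to propargyl change on the amide-type nitrogen's side chain gives a 1.4-fold lower number from compound 3 to compound 4 (0.14 log units; within the scatter), the first direct reading of this change, and it leaves compounds 3 and 4 within the scatter of each other. Ethynyl and vinyl carry the same count of heavy atoms and differ here in a triple bond against a double bond, so on a saturated chain carbon bound to an amide-type nitrogen, this swap produces no difference that this assay can separate from repeat-to-repeat noise. What is known about these compounds offers no explanation for this result, and the one available note on structure concerns only a difference in configuration.

Going by these compounds, it remains open whether a larger replacement at the same place, such as a carboxylic acid, an amine or a phenyl group in place of ethynyl, would shift the number beyond the scatter. On these data alone, it is also open whether the configuration effect seen earlier, a 3.0-fold lower number from compound 1 to compound 2 (0.48 log units; beyond the scatter), would appear in the same way on the core of compound 4.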